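Working notes: tolerance limits and a halogen swap

The source may report more compounds than this note shows. Statements on the series, on what has been measured and on what is new or still open speak of the compounds shown alone.

Measured so far:
- Compound 1 `COc1nc(-c2ccc(Cl)cc2)ccc1[C@@H](c1ccccc1)[C@@](O)(CCN(C)C)c1cccc2ccccc12`: in a toxicity assay on Vero cells (Chlorocebus sabaeus) for cytotoxicity (a lower number here means that less compound is tolerated, a higher number that more compound is tolerated), compound 1 gives > 50 ug/mL, which is a limit of the assay and not a number.
- Compound 2 `COc1ncc(-c2ccccc2)cc1[C@@H](c1ccccc1)[C@@](O)(CCN(C)C)c1cccc2ccccc12`: in this assay compound 2 gives > 50 ug/mL, again a limit of the assay.
- Compound 3 `COc1ncc(-c2ccccc2)cc1[C@@H](c1ccccc1)[C@@](O)(CCN(C)C)c1cccc(F)c1F`: in this assay compound 3 gives > 50 ug/mL, also a limit of the assay.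

Compound 1 therefore stands only at a limit, and the same holds for the other two members: all three sit at the limit of > 50 ug/mL in this assay, at which 3 of the 3 values shown sit. For the measured compounds named here, the single step between measured compounds, a step that the two limits leave unreadable from compound 2 to compound 3, cannot be read because both ends are limits, and it concerns a different place in the core than the change considered here.

Compound 4 `COc1nc(-c2ccccc2F)ccc1[C@@H](c1ccccc1)[C@@](O)(CCN(C)C)c1cccc2ccccc12` differs from compound 1 by 2-fluorophenyl in place of 4-chlorophenyl on an aromatic carbon. Going by the values given here, no measured step bears on this change. Since every value in the series stands at the limit, the expectation for compound 4 in this assay is that it also reaches the limit, estimated at 60 ug/mL with a range of 30 ug/mL to 120 ug/mL. The step that the limit leaves unreadable from compound 1 to compound 4 is expected to be none beyond the scatter, most likely reported as a limit.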

Compound 4, half-maximal cytotoxic concentration: > 50 ug/mL
Compound 4: only a limit was reported; the forecaster's own chance of this, stated with the estimate: 85%; the middle value does not contradict the limit.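

In this assay no new step can be read between compound 1 and compound 4, since both stand at a limit of the assay: the limit of > 50 ug/mL in this assay, at which 4 of the 4 values shown sit.

The compounds shown leave open where the cytotoxic concentration of any of them lies, and whether 2-fluorophenyl in place of 4-chlorophenyl changes it at all.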